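The compounds below may be only part of what the source reports. "The series", "measured", "known", "first", "only" and "open" are said of these compounds alone.

Measured in a functional assay on L1210 cells (Mus musculus) for cytotoxicity; a lower number here means a stronger inhibitor, a higher number a weaker inhibitor:
- compound 1 `CC1=C(CCC(C)(O)/C=C/C/C(=C/CC2OC(=O)C=C2CO)CO)C(C)(C)CCC1`: 2.8 ug/mL
- compound 2 `CC(=O)OC/C(=C\C[C@H]1OC(=O)C=C1CO)CC/C=C(\C)CCC1=C(C)CCCC1(C)C`: 3 ug/mL

Compound 2, at 3 ug/mL, stands level with compound 1, at 2.8 ug/mL, because the two numbers lie within the usual scatter. Compound 3 `CC1=C(CC/C(C)=C/CC/C(=C/C[C@H]2OC(=O)C=C2CO)CO)C(C)(C)CCC1` has not yet been measured. It has hydrogen in place of acetyl on an oxygen on a saturated carbon, turning acetoxymethyl into hydroxymethyl (hydrogen in place of acetyl on an oxygen on a saturated carbon). For the measured compounds named here, no measured pair shows this change, so no step beyond the scatter is expected in this assay. The estimate amounts to a 1.1-fold lower number from compound 2 to compound 3 (0.03 log units; within the scatter). For compound 3 the expected value is 2.8 ug/mL, with an estimated range from 1.2 ug/mL to 6.5 ug/mL.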

Compound 3, half-maximal inhibitory concentration: 1.7 ug/mL
For compound 3 the middle estimate is 1.6-fold (0.22 log units) above the measured one, and the stated range covers the measured number.
By their numbers in this assay, from the lowest: compounds 3, 1 and 2 (each within the scatter of the next).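

In this assay, for the compounds shown here, turning acetoxymethyl into hydroxymethyl gives a 1.8-fold lower number from compound 2 to compound 3 (0.25 log units; within the scatter), the first direct look at this change. At this position, then, the acetyl group can be removed without a step beyond the scatter, so the acetylated and free forms cannot be told apart here. No independent measurement bears on the reason for this result. Still open, from the compounds shown here alone, is whether a different group on this oxygen, such as a methyl ether or a longer benzoyl ester, would give a clear step. An amine in place of the hydroxy is equally untested among the compounds shown.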